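The source may hold more compounds than are shown below. What is called first, only, known or untested is meant among the compounds shown, and "the series" means these compounds.

Series notes, cytotoxicity.

Compound 1 `CC(C)[C@H](NC(=S)Nc1ccccc1)c1nc2ccccc2[nH]1` is the reference point. In a functional assay on A549 cells (Homo sapiens) for cytotoxicity, read by MTT assay (a lower number here means a stronger inhibitor, a higher number a weaker inhibitor), compound 1 gives 5200 nM. Compound 3 `C[C@H](NC(=S)Nc1ccccc1)c1nc2ccccc2[nH]1` keeps the same core and differs from compound 1 by one change only: methyl in place of isopropyl on a saturated chain carbon bound to an amide-type nitrogen and an aromatic carbon. In this assay compound 3 gives 188000 nM. That change carries a large cost in this assay: a 36-fold higher number from compound 1 to compound 3 (1.56 log units; beyond the scatter), so in this pair the larger group on the chain carbon clearly does better than the smaller one, and the gap stands well beyond the scatter.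

Compound 2 `CC(C)[C@@H](NC(=S)Nc1cc(C(F)(F)F)cc(C(F)(F)F)c1)c1nc2ccccc2[nH]1` is the second anchor. In this assay compound 2 gives 22400 nM, a number that sits between compound 1 and compound 3, beyond the scatter from both. The difference between the core of compound 2 and the core of compound 1 is not broken down here.

Compound 4 `C[C@@H](NC(=S)Nc1cc(C(F)(F)F)cc(C(F)(F)F)c1)c1nc2ccccc2[nH]1` is not yet measured. It stands to compound 2 as compound 3 stands to compound 1: methyl in place of isopropyl on a saturated chain carbon bound to an amide-type nitrogen and an aromatic carbon. The place is the same in both pairs, so this is the same change made on a second core. Going by the values given here, the only read on its effect is the single step from compound 1 to compound 3, and nothing in the set shows the change behaving differently on the core of compound 2.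

The expectation therefore rests on compound 1 and compound 3, a 36-fold higher number from compound 1 to compound 3 (1.56 log units; beyond the scatter), transferred to compound 2 and its value 22400 nM. The step from compound 2 to compound 4 in this assay is expected to be of similar size, a 22-fold higher number from compound 2 to compound 4 (1.35 log units; beyond the scatter). For compound 4 the estimate in this assay is 500000 nM, with a plausible range from 150000 nM to 1500000 nM.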

Compound 4, half-maximal inhibitory concentration: 15200 nM
Compound 4: the middle estimate sits 33-fold (1.52 log units) above what was measured; measured number below the stated range.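

In this assay, methyl in place of isopropyl on the core of compound 2 gives a 1.5-fold lower number from compound 2 to compound 4 (0.17 log units; within the scatter), so on this core the change leaves the number within the scatter, in contrast to the large cost seen on the core of compound 1. Going by these compounds alone, the change on the saturated chain carbon therefore does not carry over from one core to the other with the same size, and the step read on one core is no guide to the step on the other: the same change on two cores in this assay, a 36-fold higher number (1.56 log units; beyond the scatter) from compound 1 to compound 3 and a 1.5-fold lower number (0.17 log units; within the scatter) from compound 2 to compound 4, 53-fold (1.73 log units) apart, beyond the scatter of two such steps. Within the data shown here, this shows that the effect of the change depends on the core in these two pairs, but it does not show which feature of the cores is responsible, and with only two pairs it says nothing about how the change would behave on a third core.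

As far as these compounds go, it remains open whether an ethyl group or a longer chain on the same chain carbon would follow the steep trend of the core of compound 1 or the flat one of the core of compound 2. From the compounds shown here alone, it also remains open whether a core carrying chlorine or a nitrile in place of trifluoromethyl would behave like either of the two cores.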